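A few compounds are considered here, and "the series" means these few. Any claim that something is new, unique, unknown or untested is made for them only; others in the source may bear on it.

Measured so far:
Compound 1 `CC1CC1C(=O)N1CCc2nc(C#Cc3ccccc3)sc2C1` in an assay on HEK293 cells for negative allosteric modulation of metabotropic glutamate receptor 5 (Homo sapiens), read by FLIPR, with a stated time of 1 h (a lower number here means a stronger inhibitor, a higher number a weaker inhibitor), gives a limit of the assay, > 10000 nM.
Compound 2 `O=C(CC1CCOCC1)N1CCc2nc(C#Cc3ccccc3)sc2C1` in this assay gives a limit, > 10000 nM.
Compound 3 `N#Cc1cccc(C(=O)N2CCc3nc(C#Cc4ccccc4)sc3C2)c1` in this assay gives a limit, > 10000 nM.

Compound 1 therefore stands only at a limit; nothing more precise is known of it, and the same holds for the two other measured compounds, all of which sit where the limit of > 10000 nM in this assay, at which 3 of the 3 values shown sit, describes. The three measured steps, a step that the two limits leave unreadable from compound 1 to compound 2, a step that the two limits leave unreadable from compound 1 to compound 3 and a step that the two limits leave unreadable from compound 2 to compound 3, cannot be sized, since each runs from one limit to another.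

Compound 4 `O=S(=O)(C1CC1)N1CCc2nc(C#Cc3ccccc3)sc2C1` differs from compound 1 in one place: cyclopropylsulfonyl in place of (2-methylcyclopropyl)carbonyl on an amine nitrogen in a ring. Among the compounds with values here, every exchange of the group on this amine nitrogen seen so far has left the value at a limit, so there is no measured step that shows any change in this assay, in either direction, beyond the scatter. The estimated step that the limit leaves unreadable from compound 1 to compound 4 is accordingly close to none. Compound 4 is expected to give about 15000 nM in this assay, within a range from 3000 nM to 60000 nM, most likely again reported as a limit.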

Compound 4, half-maximal inhibitory concentration: 34 nM
Compound 4: the middle estimate sits 440-fold (2.64 log units) above what was measured; measured number below the stated range.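

Exchanging (2-methylcyclopropyl)carbonyl for cyclopropylsulfonyl on this amine nitrogen gives, in this assay, an at least 290-fold lower number from compound 1 to compound 4 (2.46 log units; beyond the scatter), so the group at this position can decide whether the compound registers as an inhibitor at all. Both groups have the same heavy-atom count and a three-membered ring of carbon, so neither of these features separates them; the entering group instead has sulfur in place of the carbonyl carbon and one more hydrogen-bond acceptor. Compound 4 is the only compound shown that gives a measured number rather than a limit in this assay: the limit of > 10000 nM in this assay, at which 3 of the 4 values shown sit.

From the compounds shown here alone, it remains open whether the sulfonyl link alone is enough or whether the cyclopropyl on it also matters, a question that a methylsulfonyl or phenylsulfonyl group could address. Going by these compounds, the steps among compound 1, compound 2 and compound 3 cannot be read, so any ranking of their groups is also open.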